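From hydroxymethyl to carboxy on compound 2

A few compounds are considered here, and "the series" means these few. Any claim that something is new, unique, unknown or untested is made for them only; others in the source may bear on it.

Among the compounds with values here, in an ADME assay on MRC5 cells (Homo sapiens) for cytotoxicity, read by fluorescence and resazurin assay, with a stated time of 3 days (a lower number here means that less compound is needed, a higher number that more compound is needed for the effect), compound 2 (`O=C1C=CC(O)(c2cc3ccccc3n2S(=O)(=O)c2ccc(CCCO)cc2)C=C1`) gives 51 nM as the lowest number measured so far. Compound 1 (`O=C1C=CC(O)(c2cc3ccc(F)cc3n2S(=O)(=O)c2ccccc2)C=C1`) gives 170 nM in the same measurement, and the gap between these two numbers lies beyond the usual scatter. For compound 3 (`N=C(N)c1ccc(-n2cc(C3(O)C=CC(=O)C=C3)nn2)cc1`) the reading is a limit, > 50000 nM and not a number.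

Compound 4 (`O=C1C=CC(O)(c2cc3ccccc3n2S(=O)(=O)c2ccc(CCC(=O)O)cc2)C=C1`) has not yet been measured. It differs from compound 2 in one place (carboxy in place of hydroxymethyl on a saturated chain carbon, two bonds along the chain from an aromatic carbon): carboxy in place of hydroxymethyl on a saturated chain carbon, two bonds along the chain from an aromatic carbon, so that 3-hydroxypropyl becomes 2-carboxyethyl.

Within the data shown here, no measured pair of compounds shows this change, so its size can only be estimated. In this assay a higher number is expected, by a step beyond the scatter, since compound 2 at 51 nM already stands at the low end of the numbers seen. The expected move is a 7.8-fold higher number from compound 2 to compound 4 (0.89 log units; beyond the scatter) on this estimate. For compound 4 the estimated value is 400 nM with an expected range from 90 nM to 2500 nM once it is measured.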

Compound 4, half-maximal effective concentration: 3300 nM
Estimate against measurement, compound 4: 8.3-fold (0.92 log units) below; measured number outside the range, above it.
By their numbers in this assay, from the lowest: compound 2; then compound 1; then compound 4. At a limit, above all of these: compound 3.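

In this assay, changing hydroxymethyl to carboxy on a saturated chain carbon, two bonds along the chain from an aromatic carbon, gives a 65-fold higher number from compound 2 to compound 4 (1.81 log units; beyond the scatter). Within the data shown here, this is the first step between measured compounds that differ in one place, and it shows that the end of this chain is not a neutral spot in this measurement: with the rest of the structure shared, a single change there moves the number by a large step, so that 3-hydroxypropyl and 2-carboxyethyl stand far apart. No measurement shown gives a reason for the size of this step, so it stands as an observation only.

As far as these compounds go, it remains open whether the step belongs to the carboxy group itself or would also appear with another group at this place, such as a methyl ester, a primary amide or an amine. Also open, from the compounds shown here alone, is whether carboxymethyl or a longer chain ending in a carboxylic acid would give a step of similar size, and whether the same change would act alike on the core of compound 1.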